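The source may report more compounds than this note shows. Statements on the series, on what has been measured and on what is new or still open speak of the compounds shown alone.

Working notes on the series. Three compounds carry the shared core: compound 1 `CCCCNc1nc(N)nc2ccn(Cc3ccc4ccccc4n3)c12`, compound 2 `COCCNc1nc(N)nc2ccn(Cc3ccccn3)c12` and compound 3 `Cc1cc(CNc2nc(N)nc3ccn(Cc4cc(C(F)(F)F)ccn4)c23)no1`. In an ADME assay on HEK293 cells (Homo sapiens) for cytotoxicity, read by ATP content, with a stated time of 6 h (a higher number here means that more compound is tolerated, a lower number that less compound is tolerated), compound 1 gives > 24000 nM, a limit of the assay rather than a number. In this assay compound 2 likewise gives > 24000 nM, again a limit. In this assay compound 3 gives > 24000 nM, also a limit. Compound 2 therefore stands where every measured member of the series stands, at the limit of > 24000 nM in this assay, at which 3 of the 3 values shown sit, and no measured number separates it from compound 1 or compound 3.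

Compound 4 `Cc1nc(COc2nc(N)nc3ccn(Cc4ccccn4)c23)no1` differs from compound 2 in one place: (5-methyl-1,2,4-oxadiazol-3-yl)methoxy in place of (2-methoxyethyl)amino on an aromatic carbon. The change is (5-methyl-1,2,4-oxadiazol-3-yl)methoxy in place of (2-methoxyethyl)amino on an aromatic carbon. Going by the values given here, no measured pair shows what such a change does in this assay; the three measured compounds sit together at a limit, so there is no step to lean on. The expectation is that a step that the limit leaves unreadable from compound 2 to compound 4 amounts to nothing beyond the usual scatter, since compound 2 sits at the limit of > 24000 nM in this assay, at which 3 of the 3 values shown sit, together with the rest of the series. Compound 4 is estimated at 30000 nM, with a range of 12000 nM to 80000 nM, and most likely returns only a limit.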

Compound 4, half-maximal cytotoxic concentration: > 24000 nM
Compound 4: a limit, no number; the forecaster's own chance of this, stated with the estimate: 85%; the middle value lies beyond the limit too.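

No step can be read between compound 2 and compound 4, since both values are limits and not numbers, and the series stays together: the limit of > 24000 nM in this assay, at which 4 of the 4 values shown sit.

The compounds shown leave open at what concentration any of them reduces ATP content in this assay, and whether any change of group shifts that concentration.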